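A few compounds are considered here, and "the series" means these few. Any claim that something is new, unique, unknown or untested is made for them only; others in the source may bear on it.

Working notes on the series, read in a functional assay on the whole organism (strain Kunming) with Mus musculus as the target, in the formalin test, with a stated time of 0.5 h; a higher number here means that more compound is needed for the effect, a lower number that less compound is needed. Compound 1 `COc1cc(OC)c(OC)cc1/C=C/COC(=O)/C=C/c1c(OC)ccc(OC)c1OC` gives <= 80 mg/kg, which is a limit of the assay and not a number. Compound 2 `COc1cc(OC)c(OC)cc1/C=C/COC(=O)/C=C/c1cc(OC)c(OC)c(OC)c1OC` gives 42.2 mg/kg. Compound 3 `COc1cc(OC)c(OC)cc1/C=C/COC(=O)/C=C/c1ccc(Br)cc1` gives 105 mg/kg, the higher of the two actual numbers, and its gap to compound 2 lies beyond the usual scatter.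

The next compound is compound 4 `COc1cccc(/C=C/C(=O)OC/C=C/c2cc(OC)c(OC)cc2OC)c1`, in which 3-methoxyphenyl stands in place of 4-bromophenyl on a double-bonded chain carbon bound to a double-bonded chain carbon (3-methoxyphenyl in place of 4-bromophenyl on a double-bonded chain carbon bound to a double-bonded chain carbon). Among the compounds with values here, no measured pair differs in one place only, so the expectation rests on thin ground. Compound 2, which also carries methoxy groups, gives 42.2 mg/kg, and this points to a moderate step toward a lower number in this assay, with less compound needed. The expected change is a 1.5-fold lower number from compound 3 to compound 4 (0.18 log units; within the scatter). For compound 4 the estimated value is 70 mg/kg, with an expected range of 35 mg/kg to 130 mg/kg.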

Compound 4, dose for half-maximal effect: > 100 mg/kg
Compound 4 ended at the assay's limit; the forecaster's own chance of this, stated with the estimate: 15%; at least 1.4-fold (0.15 log units) between middle value and limit.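

Compound 4 gives > 100 mg/kg in this assay, which is a limit of the assay and not a number. Within the data shown here, no step can therefore be read between compound 3 and compound 4. The compounds shown leave open what effect any single change on the shared core has on the dose needed in this assay.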